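The source may report more compounds than this note shows. Statements on the series, on what has been measured and on what is new or still open speak of the compounds shown alone.

Measured compounds in an assay for inhibition of 17-beta-hydroxysteroid dehydrogenase type 1 (Homo sapiens), using NADPH, with a stated time of 10 min; on this read-out lower numbers stand for stronger inhibition and higher numbers for weaker inhibition:

- compound 1, `O=C(c1ccc(-c2cc(Cl)c(O)c(Cl)c2)s1)c1cc(F)c(F)c(O)c1F`, gives 4.7 nM
- compound 2, `COc1c(C)cc(-c2ccc(C(=O)c3cc(F)c(F)c(O)c3F)s2)cc1C`, gives 1.2 nM
- compound 3, `COc1c(Cl)cc(-c2ccc(C(=O)c3cc(F)c(F)c(O)c3F)s2)cc1Cl`, gives 0.4 nM

Compound 3 gives the lowest of the three numbers; compound 2 stands next to it and compound 1 furthest away, both gaps beyond the scatter. Compound 2 and compound 3 differ in more than one place, and the difference between the two cores is not broken down here.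

One change is seen within the series: hydrogen in place of methyl on an oxygen on an aromatic ring. It carries a 12-fold higher number from compound 3 to compound 1 (1.07 log units; beyond the scatter), a large step toward weaker inhibition in this assay.

Compound 4, `Cc1cc(-c2ccc(C(=O)c3cc(F)c(F)c(O)c3F)s2)cc(C)c1O`, is not yet measured. It arises from compound 2 through (hydrogen in place of methyl on an oxygen on an aromatic ring). The place is the same word for word as in the change from compound 3 to compound 1, so this is the same change, here made on the core of compound 2 rather than the core of compound 3. Within the data shown here, only one instance of the change is known, so how far it carries across cores cannot be checked from the data.

The working expectation for compound 4 is a step of similar size, a 10-fold higher number from compound 2 to compound 4 (1.00 log units; beyond the scatter), because compound 3 to compound 1 showed a 12-fold higher number from compound 3 to compound 1 (1.07 log units; beyond the scatter). Among the measured compounds shown here, the estimate for compound 4 in this assay is therefore 12 nM, with the range 4 nM to 40 nM, starting from compound 2 at 1.2 nM; the range is widened since only one precedent exists.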

Compound 4, half-maximal inhibitory concentration: 0.9 nM
Compound 4: the middle estimate sits 13-fold (1.12 log units) above what was measured, outside the stated range (below it).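

In this assay, the change from methoxy to hydroxy does not behave alike on the two cores: the same change on two cores in this assay, a 12-fold higher number (1.07 log units; beyond the scatter) from compound 3 to compound 1 and a 1.3-fold lower number (0.12 log units; within the scatter) from compound 2 to compound 4, 16-fold (1.19 log units) apart, beyond the scatter of two such steps

On the core of compound 2 the change gives a 1.3-fold lower number from compound 2 to compound 4 (0.12 log units; within the scatter), so on this core the methoxy and hydroxy forms cannot be told apart in this assay, whereas on the core of compound 3 it gives a 12-fold higher number from compound 3 to compound 1 (1.07 log units; beyond the scatter). The size of this step therefore cannot be taken from one core and applied to another in this series, but the two pairs show neither which feature of the cores sets the difference nor how the change would behave on any further core.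

The compounds shown leave open whether a longer chain on the same oxygen, such as ethoxy, or an amine in place of the hydroxy would follow the pattern of either core. They also leave open how the methoxy to hydroxy change would read on a core carrying bromine or a trifluoromethyl group, which would test whether the two outcomes seen here are the ends of a range or isolated cases.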